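Urea series: from ethenyl amides back to an aryl amide

A few compounds are considered here, and "the series" means these few. Any claim that something is new, unique, unknown or untested is made for them only; others in the source may bear on it.

Measured so far:
compound 1, `CC(NC(=O)c1cccc(-c2ccc(NC(=O)Nc3ccc(Cl)c(C(F)(F)F)c3)cc2)c1)c1ccccc1`: in a functional assay on MX1 cells (Homo sapiens) for inhibition, read by MTT assay, with a stated time of 120 h (on this read-out higher numbers stand for weaker inhibition and lower numbers for stronger inhibition), compound 1 gives 5240 nM.
compound 2, `CNC(=O)/C=C/c1ccc(NC(=O)Nc2ccc(Cl)c(C(F)(F)F)c2)cc1`: in this assay compound 2 gives 13800 nM.
compound 3, `CNC(=O)/C(C)=C/c1ccc(NC(=O)Nc2ccc(Cl)c(C(F)(F)F)c2)cc1`: in this assay compound 3 gives > 50000 nM, which is a limit of the assay and not a number, as the limit of > 50000 nM in this assay, at which 1 of the 3 values shown sits, records.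

Compound 3 therefore stands at the weak end of what has been measured, with only a bound known. Compound 4, `CNC(=O)c1cccc(-c2ccc(NC(=O)Nc3ccc(Cl)c(C(F)(F)F)c3)cc2)c1`, carries 3-(methylcarbamoyl)phenyl in place of 2-(methylcarbamoyl)prop-1-en-1-yl on an aromatic carbon. Going by the values given here, the only measured single-place step is an at least 3.6-fold higher number from compound 2 to compound 3 (0.55 log units; beyond the scatter), a modest worsening on adding the methyl to the ethenyl chain. It bears on compound 4 only indirectly: the change here removes the whole branched chain rather than the methyl alone, so the step from compound 2 is a lower bound on how much can be regained. Among the compounds with values here, compound 1, which also carries an aryl-borne carbamoyl, gives 5240 nM; no step between compound 1 and compound 4 is computed here, and the two simply sit in the same region. The expected step is an at least 6.2-fold lower number from compound 3 to compound 4 (0.79 log units; beyond the scatter), towards a stronger inhibition. For compound 4 the estimated value is 8000 nM, with a range from 2000 nM to 30000 nM.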

Compound 4, half-maximal inhibitory concentration: > 50000 nM
Compound 4: no number, only a limit (the forecaster's own chance of this, stated with the estimate: 10%); middle value at least 6.2-fold (0.79 log units) from the limit.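

In this assay compound 4 is recorded only as a limit of the assay, not a number, and the step to it from compound 3, itself a limit, cannot be read: the limit of > 50000 nM in this assay, at which 2 of the 4 values shown sit.

Putting 3-(methylcarbamoyl)phenyl in place of 2-(methylcarbamoyl)ethenyl gives an at least 3.6-fold higher number from compound 2 to compound 4 (0.55 log units; beyond the scatter), so in this series the aromatic ring on the methyl amide does not match the unbranched ethenyl amide. Methyl in place of 1-phenylethyl on the amide nitrogen gives an at least 9.5-fold higher number from compound 1 to compound 4 (0.97 log units; beyond the scatter), which shows that the aryl amide alone does not account for the value of compound 1, and that the group on that nitrogen matters.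

Which part of 1-phenylethyl counts stays open, as a benzyl group or a plain ethyl on the same nitrogen would be needed to separate the phenyl ring from the branched carbon. Also open, as far as these compounds go, is how a carboxylic acid in place of the amide would read here.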